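The source may report more compounds than this note shows. Statements on the series, on what has been measured and on what is new or still open speak of the compounds shown alone.

Compound 2 `CC(C)(C)C1=NN(c2ccc(F)cc2F)C(c2ccc(O)cc2)C1` stands lowest of the two numbers in an assay on isolated protein for inhibition of protein kinase C zeta type (Homo sapiens), with a stated time of 4 min, tested at 62.5 uM (a higher number here means more inhibition at the concentration tested (going by the name of the read-out), a lower number less inhibition), giving 68%, while compound 1 `CC(C)(C)C1=NN(c2cccc(F)c2)C(c2ccc(O)cc2)C1` gives 98.1%. Going by the values given here, the one measured step bearing on the next change is a number 30.1 percentage points lower from compound 1 to compound 2 (beyond the scatter), large and downward. Compound 3 `CC(C)(C)C1=NN(c2ccc(F)c(F)c2F)C(c2ccc(O)cc2)C1` differs from compound 2 by fluoro in place of hydrogen on an aromatic carbon, on an aromatic carbon ortho to two fluoro groups. Among the compounds with values here, only that single fluorine-pattern step informs the expectation, so a further fall of moderate size is expected, with wide uncertainty. Compound 3 is expected to give 52%, in the range 25% to 80%. The expected step is a number 16 percentage points lower from compound 2 to compound 3 (beyond the scatter).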

Compound 3, a percentage reported as inhibition, at one concentration (the size of the read-out at that concentration, not a potency): 91.7%
Beside the measured number, compound 3's estimate is 39.7 percentage points below it, and the stated range ends below it.
By their numbers in this assay, from the lowest: compound 2; then compounds 3 and 1 (each within the scatter of the next).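

In this assay fluoro in place of hydrogen on this aromatic carbon, ortho to two fluoro groups, gives a number 23.7 percentage points higher from compound 2 to compound 3 (beyond the scatter) and so moves the read-out upward. The earlier step on this ring ran downward, so the fluorine pattern does not move the number in one direction, and adding fluoro does not track with less inhibition. No measurement given here accounts for the rise.

Open, as far as these compounds go, is whether a methoxy group or an amine on this carbon would also raise the number. Also open, from the compounds shown here alone, is whether the rise depends on the two fluoro groups already present.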